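A Methoxy Group Added to Compound 3

A few compounds are considered here, and "the series" means these few. Any claim that something is new, unique, unknown or untested is made for them only; others in the source may bear on it.

Among the measured compounds shown here, in a functional assay on the whole organism (strain BALB/c) with Mus musculus as the target, with a stated time of 4 h (on this read-out lower numbers stand for an effect already at smaller amounts and higher numbers for an effect only at larger amounts of compound), compound 3 (`CC1=C(CN2CC(C(=O)O)C2)CCc2cc(OCc3ccc(CC(C)C)cc3)ccc21`) gives 0.39 mg/kg as the only actual number so far. Compound 2 (`CC1=C(CN2CC(C(=O)O)C2)CCc2cc(OCC3Cc4ccccc4C3)ccc21`) stands at > 1 mg/kg which is a limit of the assay. Compound 1 (`CC1=C(CN2CC(C(=O)O)C2)CCc2cc(OCC3CCc4ccccc4C3)ccc21`) shows "not determined" (no result reported) as its entry. Compared with compound 3, compound 4 (`COc1cc(CC(C)C)ccc1COc1ccc2c(c1)CCC(CN1CC(C(=O)O)C1)=C2C`) carries methoxy in place of hydrogen on an aromatic carbon, ortho to a large group and meta to an isobutyl group (methoxy in place of hydrogen on an aromatic carbon). For the measured compounds named here, the only measured step is an at least 2.5-fold lower number from compound 2 to compound 3 (0.40 log units; beyond the scatter) with 4-isobutylphenyl in place of 2,3-dihydro-1H-inden-2-yl, a different exchange that gives no direct size for adding methoxy. In this assay the expected step is therefore a 1.2-fold higher number from compound 3 to compound 4 (0.06 log units; within the scatter) with no shift beyond the scatter foreseen. Compound 4 is estimated to give 0.45 mg/kg with 0.14 mg/kg to 1.4 mg/kg as the expected range.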

Compound 4, dose for half-maximal effect: 0.0092 mg/kg
The estimate for compound 4 lay 49-fold (1.69 log units) above the measured number, and the stated range ends above it.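

In this assay, the aromatic carbon ortho to a large group and meta to an isobutyl group proves highly sensitive: methoxy in place of hydrogen gives a 42-fold lower number from compound 3 to compound 4 (1.63 log units; beyond the scatter), the large change coming from only 2 heavy atoms. The earlier step exchanged a whole group, whereas this one shows that a small addition to the aromatic ring of compound 3 can shift the dose strongly. Nothing shown explains why methoxy has this effect. Going by these compounds, whether ethoxy, hydroxyl or a fluorine atom on this carbon would act the same way remains open. So does whether methoxy on another carbon of this ring would.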